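Dienamide series: amide substituent swap at the carbonyl

The compounds below may be only part of what the source reports. "The series", "measured", "known", "first", "only" and "open" are said of these compounds alone.

Compound 2 `CCN1CCN(C(=O)/C=C/C=C/[C@H](O)Cc2ccc(OC)c(OC)c2)CC1` holds the lowest of the two numbers in a functional assay on A549 cells (Homo sapiens) for antiproliferative activity, read by sulforhodamine B assay, with a stated time of 48 h; a higher number here means a weaker inhibitor, a lower number a stronger inhibitor; in this assay compound 2 gives 15700 nM. Compound 1 `COc1ccc(CNC(=O)/C=C/C=C/[C@H](O)Cc2ccc(OC)c(OC)c2)cc1` gives 16800 nM in this assay, within the scatter of compound 2, so no order can be read between them. Compound 3 `CCNC(=O)/C=C/C=C/[C@H](O)Cc1ccc(OC)c(OC)c1` is not yet measured in this assay and differs from compound 2 in one place: ethylamino in place of 4-ethylpiperazin-1-yl on a carbonyl carbon. Within the data shown here, no measured step on this change exists. Compound 3 is expected to give 20000 nM in this assay, with a range of 8000 nM to 50000 nM. The expected step of a 1.3-fold higher number from compound 2 to compound 3 (0.11 log units; within the scatter) is small, not beyond the scatter, because compound 1 at 16800 nM and compound 2 at 15700 nM lie close together across two unlike amide groups.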

Compound 3, half-maximal inhibitory concentration: 13800 nM
For compound 3 the middle estimate is 1.4-fold (0.16 log units) above the measured one; low and high end bracket the measured number.
By their numbers in this assay, from the lowest: compounds 3, 2 and 1 (each within the scatter of the next).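

Neither swap on the carbonyl carbon separates the compounds in this assay. Ethylamino, with 3 heavy atoms and no ring, in place of 4-ethylpiperazin-1-yl, with 8 heavy atoms and one ring, gives a 1.1-fold lower number from compound 2 to compound 3 (0.06 log units; within the scatter), and methyl in place of 4-methoxyphenyl gives a 1.2-fold lower number from compound 1 to compound 3 (0.09 log units; within the scatter). No measurement at hand accounts for these small steps.

Going by these compounds, whether a longer alkyl chain or a chain ending in a carboxylic acid in this place would move the number stays open. Also open, on these data alone, is whether a primary amine would do so.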